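From 4-fluorophenyl to 3-fluorophenyl on the shared core

A few compounds are considered here, and "the series" means these few. Any claim that something is new, unique, unknown or untested is made for them only; others in the source may bear on it.

Measured in a functional assay on Raji cells (Homo sapiens) for cytotoxicity, with a stated time of 72 h (a higher number here means that more compound is needed for the effect, a lower number that less compound is needed), so far:
- compound 1 `C=C[C@@](C)(/C=C/c1ccc(Nc2ccc(Cl)c(Cl)c2)cc1)CCC=C(C)C`: > 26000 nM (a limit)
- compound 2 `C=C[C@@](C)(/C=C/c1ccc(-c2ccc(F)cc2)cc1)CCC=C(C)C`: > 26000 nM (a limit)

In this assay compound 2 stands at > 26000 nM as a limit and not as a number. Among the compounds with values here, neither measured compound has a readable value, and the whole series so far sits at one place: the limit of > 26000 nM in this assay, at which 2 of the 2 values shown sit. Within the data shown here, the only measured step is a step that the two limits leave unreadable from compound 1 to compound 2 and it gives no size to carry forward.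

Compound 3 `C=C[C@@](C)(/C=C/c1ccc(-c2cccc(F)c2)cc1)CCC=C(C)C` differs from compound 2 in one place: 3-fluorophenyl in place of 4-fluorophenyl on an aromatic carbon. The fluorine-bearing ring therefore keeps its counted make-up and its attachment, para to a large group, and only the name of the group changes. Among the measured compounds shown here, no measured step covers a change of this kind, so no direction can be read from the data, and no step beyond the scatter is expected. An estimated a number no higher from compound 2 to compound 3 (the limit leaves the size open) is what this expectation amounts to. A report as a limit is the likeliest outcome in this assay for the next measurement. For compound 3 the expected value is 26000 nM with an estimated range from 13000 nM to 52000 nM for the reading.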

Compound 3, half-maximal effective concentration: > 26000 nM
Compound 3 gave a limit, no number; the forecaster's own chance of this, stated with the estimate: 80%; the middle value sits exactly at the limit.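

In this assay compound 3 gives > 26000 nM, a limit and not a number, and no new step can be read among compound 1, compound 2 and compound 3. The compounds shown leave open whether any change on the shared core gives a readable value in this assay, and how 3-fluorophenyl compares with 4-fluorophenyl.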